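Methoxy in Place of Methyl: Expected Paw Edema Inhibition

The compounds below may be only part of what the source reports. "The series", "measured", "known", "first", "only" and "open" are said of these compounds alone.

Compound 1 `Cc1ccc(-c2nn(-c3ccc(Cl)cc3)cc2C=O)cc1`: 49.9%
Compound 2 `Cc1ccc(-c2nn(-c3ccc(S(N)(=O)=O)cc3)cc2/C=N\c2ccc(Cl)cc2)cc1`: 69.1%
Compound 3 `Cc1ccc(-c2nn(-c3ccc(Cl)cc3)cc2/C=C\C(=O)c2ccc(Cl)cc2)cc1`: 49.2%

In a functional assay on the whole organism (strain Wistar albino) for inhibition, with Rattus norvegicus as the target, read by paw edema, with stated times of 1 h and 2 h, at a dose of 0.32 mmol/kg by the intraperitoneal route (a higher number here means more inhibition at the dose given (going by the name of the read-out), a lower number less inhibition), compound 1 gives 49.9% and compound 2 gives 69.1%. Compound 3 gives 49.2%, the lowest number of the three, though its gap to compound 1 falls within the usual scatter, while compound 2 stands beyond the scatter above it.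

Compound 4 `COc1ccc(-c2nn(-c3ccc(Cl)cc3)cc2/C=C\C(=O)c2ccc(Cl)cc2)cc1` differs from compound 3 in one place: methoxy in place of methyl on an aromatic carbon. Among the measured compounds shown here, no pair of measured compounds differs in just this way, so the data give no direct reading of how this change acts in this assay. The expectation is a step of no size beyond the scatter, a number 0.8 percentage points higher from compound 3 to compound 4 (within the scatter), in either direction. Compound 4 is therefore estimated at 50%, with a range from 40% to 62%.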

Compound 4, a percentage reported as inhibition, in the whole organism at one dose (the size of the read-out at that dose, not a potency): 53.7%
Estimate against measurement, compound 4: 3.7 percentage points below; the measured number falls inside the stated range.
By their numbers in this assay, from the lowest: compounds 3, 1 and 4 (each within the scatter of the next); then compound 2.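

Going from 4-methylphenyl to 4-methoxyphenyl gives a number 4.5 percentage points higher from compound 3 to compound 4 (within the scatter) in this assay, the first direct reading of this change. At this place, para to a large group, the entering oxygen and its hydrogen-bond acceptor therefore come with no step beyond the scatter. No evidence bears on this result.

As far as these compounds go, whether an amine, a carboxylic acid or a longer chain such as ethoxy at this place would give a step beyond the scatter remains open. Also open, from the compounds shown here alone, is whether the same change would read alike on compound 2.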